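Aryl amide swap in the cyclopropane diamide series

This account rests on a few compounds, and the source may have more. Where it says the series, first, only, none or still open, it means among the compounds named here.

Values in a functional assay on A549 cells (Homo sapiens) for inhibition, read by CCK-8 assay, with a stated time of 72 h, tested at 10 uM; on this read-out higher numbers stand for more inhibition of growth at the one concentration tested and lower numbers for less inhibition of growth:
- compound 1 `Cc1cccc(NC(=O)C2(C(=O)Nc3ccc(Nc4ncc5cc(C(=O)N(C)C)n(C6CCCC6)c5n4)cc3)CC2)c1`: 86.1%
- compound 2 `CN(C)C(=O)c1cc2cnc(Nc3ccc(NC(=O)C4(C(=O)Nc5ccccc5F)CC4)cc3)nc2n1C1CCCC1`: 88.6%
- compound 3 `COC(=O)c1cccc(NC(=O)C2(C(=O)Nc3ccc(Nc4ncc5cc(C(=O)N(C)C)n(C6CCCC6)c5n4)cc3)CC2)c1`: 91%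

Compound 3 is not separated from the other two measured compounds, as the steps show: a number 4.9 percentage points higher from compound 1 to compound 3 (within the scatter) and a number 2.4 percentage points higher from compound 2 to compound 3 (within the scatter).

Compound 4 `CN(C)C(=O)c1cc2cnc(Nc3ccc(NC(=O)C4(C(=O)Nc5ccc(C(F)(F)F)cc5)CC4)cc3)nc2n1C1CCCC1` carries 4-(trifluoromethyl)phenyl in place of 3-(methoxycarbonyl)phenyl on an amide-type nitrogen. The closest precedents are the other swaps of the group on this nitrogen, a number 2.5 percentage points higher from compound 1 to compound 2 (within the scatter) and again the step to compound 3 above. Going by the values given here, no measured compound carries the entering group, so the expectation is loose. In this assay, no shift beyond the scatter is expected, with an estimated a number 4 percentage points lower from compound 3 to compound 4 (within the scatter). The estimate for compound 4 is 87%, with an expected range of 77% to 95%.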

Compound 4, percent growth inhibition at one concentration: 87.9%
Compound 4: middle estimate off by 0.9 percentage points, on the low side; measured number inside the range.
By their numbers in this assay, from the lowest: compounds 1, 4, 2 and 3 (each within the scatter of the next).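

In this assay, the 4-(trifluoromethyl)phenyl group on the amide-type nitrogen is not separated from any of the three earlier aryl groups (a number 3.1 percentage points lower from compound 3 to compound 4 (within the scatter)) and (a number 0.7 percentage points lower from compound 2 to compound 4 (within the scatter)) and (a number 1.8 percentage points higher from compound 1 to compound 4 (within the scatter)). At this position, a group with 0 hydrogen-bond acceptors reads the same as the 3-(methoxycarbonyl)phenyl group with 2. Nothing available explains this flat response.

Still open, as far as these compounds go, is whether a carboxylic acid or an amine on the phenyl ring, or an open alkyl chain in its place, would leave this range. A single concentration also cannot rank these compounds.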